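The source may hold more compounds than are shown below. What is called first, only, known or untested is meant among the compounds shown, and "the series" means these compounds.

Compound 1 `O=C(Cn1nnc(-c2ccccc2)n1)Nc1cc(C2CC2)nn1C1CCCCC1` and compound 2 `Cc1cc(NC(=O)Cn2nnc(-c3cccc(Cl)c3)n2)n(C2CCCCC2)n1` share one core. In an assay on HEK293 cells for activation of Kir3.1/Kir3.2 (Homo sapiens), read by thallium flux (a higher number here means that more compound is needed for the effect, a lower number that less compound is needed), compound 1 gives 271 nM, and compound 2 gives 300 nM, the higher of the two numbers, although its gap to compound 1 lies within the scatter. Compound 3 `Cc1cc(NC(=O)Cn2nnc(-c3ccccc3F)n2)n(C2CCCCC2)n1` differs from compound 2 in one place: 2-fluorophenyl in place of 3-chlorophenyl on an aromatic carbon. Among the compounds with values here, no measured pair shows this change, so its direction is open. The expected step in this assay is a 1.2-fold higher number from compound 2 to compound 3 (0.07 log units; within the scatter), small and not clearly beyond the scatter. For compound 3 the estimate in this assay is 350 nM, with a range from 150 nM to 900 nM.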

Compound 3, half-maximal effective concentration: 187 nM
For compound 3 the middle estimate is 1.9-fold (0.27 log units) above the measured one; measured number inside the range.
By their numbers in this assay, from the lowest: compounds 3, 1 and 2 (each within the scatter of the next).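

In this assay, within the data shown here, the exchange of 3-chlorophenyl for 2-fluorophenyl on the aromatic carbon gives a 1.6-fold lower number from compound 2 to compound 3 (0.21 log units; within the scatter), the first reading of a one-place change at this position. The two groups cannot be told apart here, so this position accepts either of them without a step beyond the scatter. Nothing available accounts for the result. As far as these compounds go, the halogen and its place on the phenyl ring change together, so their separate contributions stay open. Also open, from the compounds shown here alone, is whether a carboxylic acid or an amine at this position would stay in the same range.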